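Cinnamamide anilinoquinazolines: aryl swap on the ethenyl arm

A few compounds are considered here, and "the series" means these few. Any claim that something is new, unique, unknown or untested is made for them only; others in the source may bear on it.

Measured so far in a functional assay on A549 cells (Homo sapiens) for antiproliferative activity, read by MTT assay, with a stated time of 48 h; on this read-out lower numbers stand for stronger inhibition and higher numbers for weaker inhibition:
compound 1 `O=C(/C=C/c1ccccc1Cl)Nc1ccc2ncnc(Nc3cccc(Br)c3)c2c1` — 6.63 ug/mL
compound 2 `COc1ccc(/C=C/C(=O)Nc2ccc3ncnc(Nc4cccc(Br)c4)c3c2)cc1` — 3.36 ug/mL

Compound 1 holds the highest number of the two in this assay; its nearest neighbour is compound 2, and the difference between them, a 2.0-fold lower number from compound 1 to compound 2 (0.30 log units; within the scatter), stays within the scatter. That step exchanges one aryl group for another on the same chain carbon, so the two measured numbers show no separation that could be read as a trend.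

Compound 3 `O=C(/C=C/c1cccs1)Nc1ccc2ncnc(Nc3cccc(Br)c3)c2c1` is the next member. Its change from compound 1 is thiophen-2-yl in place of 2-chlorophenyl on a double-bonded chain carbon bound to a double-bonded chain carbon. Going by the values given here, the only measured step that bears on it is the aryl exchange from compound 1 to compound 2, which is the step noted above and lies within the scatter. On that basis no step beyond the scatter is expected for compound 3, and the expected shift is a 1.3-fold lower number from compound 1 to compound 3 (0.12 log units; within the scatter) in this assay.

For compound 3 the estimate in this assay is 5 ug/mL, with a range from 2 ug/mL to 12.5 ug/mL.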

Compound 3, half-maximal inhibitory concentration: 4.66 ug/mL
Estimate against measurement, compound 3: 1.1-fold (0.03 log units) above, and the stated range covers the measured number.
By their numbers in this assay, from the lowest: compounds 2, 3 and 1 (each within the scatter of the next).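

In this assay, going by these compounds alone, the place on a double-bonded chain carbon bound to a double-bonded chain carbon now also carries a five-membered aromatic ring with 1 hetero atom, where the earlier compounds carried only six-membered carbon rings. Thiophen-2-yl gives a 1.4-fold lower number from compound 1 to compound 3 (0.15 log units; within the scatter) and a 1.4-fold higher number from compound 2 to compound 3 (0.14 log units; within the scatter) and both steps lie within the scatter, so neither exchange of ring, from 2-chlorophenyl or from 4-methoxyphenyl, separates compound 3 from the others. No measured data on the groups bear on this result.

Still open, from the compounds shown here alone, is whether a group other than an aromatic ring at this place, such as a dimethylamino group, a carboxylic acid or a cyclohexyl ring, would give a step beyond the scatter. The compounds shown also leave open whether changing the 3-bromophenyl-bearing part of the shared core would do so.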